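A few compounds are considered here, and "the series" means these few. Any claim that something is new, unique, unknown or untested is made for them only; others in the source may bear on it.

Compound 1 `COc1ccc2ncc(S(=O)(=O)c3ccc(C)c(Cl)c3)c(N3CCC(C)CC3)c2c1` stands highest of the two numbers in an assay on isolated protein for displacement of a labelled ligand from metabotropic glutamate receptor 5 (Homo sapiens), with a stated time of 60 min, tested at 1 uM (on this read-out lower numbers stand for less inhibition and higher numbers for more inhibition at the one concentration tested (going by the name of the read-out)), where compound 1 gives 85%; compound 2 `CCOC(=O)C1CCN(c2c(S(=O)(=O)c3ccccc3)cnc3ccccc23)CC1` gives 33%, a gap well beyond the usual scatter. Compound 3 `COc1ccc2ncc(S(=O)(=O)c3ccc(Cl)c(Cl)c3)c(N3CCC(C)CC3)c2c1` differs from compound 1 by chloro in place of methyl on an aromatic carbon. Within the data shown here, no step between measured compounds is known for a change of this kind, so the account rests on compound 1 alone. The expected step of a number 3 percentage points lower from compound 1 to compound 3 (within the scatter) is small, falling within the scatter, with no direction claimed beyond it. Compound 3 is estimated at 82%, with a range from 65% to 95%, resting on compound 1 at 85%.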

Compound 3, a percentage reported as inhibition, at one concentration (the size of the read-out at that concentration, not a potency): 87%
Estimate against measurement, compound 3: 5 percentage points below, and the stated range covers the measured number.
By their numbers in this assay, from the lowest: compound 2; then compounds 1 and 3 (each within the scatter of the next).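

Chloro in place of methyl on this aromatic carbon, para to a large group, gives in this assay a number 2 percentage points higher from compound 1 to compound 3 (within the scatter), so the 3-chloro-4-methylphenyl and 3,4-dichlorophenyl compounds cannot be told apart here. Among these compounds, this is the first single-place step at this position, which compounds 1 and 2, differing in more than one place, could not provide. Nothing at hand bears on the cause of this result. On these data alone, whether a nitrile, a carboxylic acid or an amine on this carbon would leave the reading unchanged stays open. So does whether the same change would be as small on the core of compound 2.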